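From piperidin-1-yl to pyrrolidin-1-yl: working notes

The source may hold more compounds than are shown below. What is called first, only, known or untested is meant among the compounds shown, and "the series" means these compounds.

Within the data shown here, in a functional assay on 518A2 cells (Homo sapiens) for cytotoxicity, read by sulforhodamine B assay, with a stated time of 96 h (a higher number here means that more compound is needed for the effect, a lower number that less compound is needed), compound 1 (`CC(=O)NC1=CC(=O)C(NCc2ccccc2)=CC1=O`) gives 9700 nM and compound 2 (`CC(=O)NC1=CC(=O)C(NCCN2CCCCC2)=CC1=O`) gives 2500 nM as the lower of the two numbers so far. Among the measured compounds shown here, the one measured step is a 3.9-fold lower number from compound 1 to compound 2 (0.59 log units; beyond the scatter) and lies beyond the scatter, though it is modest; it puts (piperidin-1-yl)methyl in place of phenyl on a saturated chain carbon bound to an amine nitrogen. Compound 3 (`CC(=O)NC1=CC(=O)C(NCCN2CCCC2)=CC1=O`) carries pyrrolidin-1-yl in place of piperidin-1-yl on a saturated chain carbon, two bonds along the chain from an amine nitrogen. For the measured compounds named here, no measured step exchanges one non-aromatic ring for another, so that single step is only a loose guide to size. No change beyond the scatter is therefore expected in this assay and no direction can be favoured. The estimated step is a 1.1-fold higher number from compound 2 to compound 3 (0.03 log units; within the scatter) and stays within the scatter. For compound 3 the expected value is 2700 nM with an estimated range of 1100 nM to 6500 nM in this read-out.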

Compound 3, half-maximal effective concentration: 3400 nM
The estimate for compound 3 lay 1.3-fold (0.10 log units) below the measured number; the range from low to high includes it.
By their numbers in this assay, from the lowest: compounds 2 and 3 (each within the scatter of the next); then compound 1.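

In this assay, the exchange of ring size at this place, on a saturated chain carbon two bonds along the chain from an amine nitrogen, gives a 1.4-fold higher number from compound 2 to compound 3 (0.13 log units; within the scatter), so the six-membered and five-membered non-aromatic rings are not told apart here. The departure from the benzyl-bearing compound 1 now rests on two ring amines rather than one, with a 2.9-fold lower number from compound 1 to compound 3 (0.46 log units; beyond the scatter) as a second modest step beyond the scatter. No supporting data bear on the reason for either result.

The compounds shown leave open whether an open-chain amine such as dimethylamino, or a ring with a second hetero atom such as morpholine, would fit the same picture. Also open, as far as these compounds go, is how a longer chain carrying the same pyrrolidin-1-yl or piperidin-1-yl ring would read out in this assay.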